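The source may report more compounds than this note shows. Statements on the series, on what has been measured and on what is new or still open speak of the compounds shown alone.

Of the compounds shown here, three have been measured in an assay on CHO cells for displacement of a labelled ligand from 5-hydroxytryptamine receptor 1B (Homo sapiens); a lower number here means a stronger inhibitor, a higher number a weaker inhibitor. Compound 3, `CN(Cc1ccc(S(C)(=O)=O)cc1)C1CCN(CCCc2c[nH]c3ccc(-n4cnnc4)cc23)CC1`, gives 140 nM, the lowest number of the three. The nearest to it is compound 2, `c1ccc(C2CCCCN2C2CCN(CCCc3c[nH]c4ccc(-n5cnnc5)cc34)CC2)cc1`, which gives 410 nM, a gap that lies beyond the usual scatter. The furthest is compound 1, `COC[C@H](NC1CCN(CCCc2c[nH]c3ccc(Cn4cncn4)cc23)CC1)c1ccc(F)cc1`, which gives 1200 nM, also beyond the scatter. On these numbers compound 3 stands as the strongest inhibitor of the three.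

Compound 4, `CN(Cc1cccs1)C1CCN(CCCc2c[nH]c3ccc(-n4cnnc4)cc23)CC1`, has not yet been measured in this assay. It differs from compound 3 in one place: thiophen-2-yl in place of 4-(methylsulfonyl)phenyl on a saturated chain carbon bound to an amine nitrogen. Within the data shown here, no pair among the measured compounds shows a change of this kind, so its size cannot be read off from any measured step. The change removes a larger group and brings in a smaller one at the same place; the expectation is a step toward a somewhat higher number, estimated at a 2.0-fold higher number from compound 3 to compound 4 (0.30 log units; within the scatter), which may still fall within the scatter. Compound 4 is therefore expected to give about 280 nM in this assay, within a range of 90 nM to 900 nM.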

Compound 4, half-maximal inhibitory concentration: 140 nM
The estimate for compound 4 lay 2.0-fold (0.30 log units) above the measured number; measured number inside the range.
By their numbers in this assay, from the lowest: compounds 3 and 4 (each within the scatter of the next); then compound 2; then compound 1.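

In this assay, putting thiophen-2-yl in place of 4-(methylsulfonyl)phenyl gives no change at the digits printed from compound 3 to compound 4 (within the scatter), the first step measured at this place, on a saturated chain carbon bound to an amine nitrogen. In this pair, neither the 10 heavy atoms of the leaving group nor its six-membered aromatic ring of carbon is needed to keep the number, and the same holds for its 2 double bonds outside aromatic rings. Nothing among the data given accounts for the absence of a measurable shift.

The compounds shown leave open whether plain phenyl, furan-2-yl or a simple methyl at this place would also leave the number in the same range. They also do not tell whether a carboxylic acid or a primary amine on the thiophene ring would move it.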